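A nitro group replaces tert-butyl in an inactive series

The source may report more compounds than this note shows. Statements on the series, on what has been measured and on what is new or still open speak of the compounds shown alone.

Measured in a functional assay on A549 cells (Homo sapiens) for cytotoxicity, read by MTT assay; a lower number here means a stronger inhibitor, a higher number a weaker inhibitor:
compound 1, `CCOC(=O)C12C(=O)OCC=C1COC2c1ccc(F)cc1`: > 1000000 nM, a limit of the assay
compound 2, `CCOC(=O)C12C(=O)OCC=C1COC2c1ccc(Br)cc1`: > 1000000 nM, a limit of the assay
compound 3, `CCOC(=O)C12C(=O)OCC=C1COC2c1ccc(C(C)(C)C)cc1`: > 1000000 nM, a limit of the assay

None of the three values is a number; all three sit at the limit of > 1000000 nM in this assay, at which 3 of the 3 values shown sit. Compound 3 therefore stands at the limit, and the other two compounds stand there with it, so no order among them can be read. The steps a step that the two limits leave unreadable from compound 1 to compound 2, a step that the two limits leave unreadable from compound 1 to compound 3 and a step that the two limits leave unreadable from compound 2 to compound 3 cannot be read either; both ends of each step sit at the limit.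

Compound 4, `CCOC(=O)C12C(=O)OCC=C1COC2c1ccc([N+](=O)[O-])cc1`, differs from compound 3 by nitro in place of tert-butyl on an aromatic carbon. Within the data shown here, no measured step bears on this change beyond the fact that every compound examined so far sits at the limit in this assay. On that basis the expected step is a number no higher from compound 3 to compound 4 (the limit leaves the size open), meaning no movement that can be resolved. Compound 4 is estimated at 1000000 nM, with a range from 100000 nM to 10000000 nM, and is most likely to be reported again only as a limit.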

Compound 4, half-maximal inhibitory concentration: 36800 nM
Beside the measured number, compound 4's estimate is 27-fold (1.43 log units) above it, outside the stated range (below it).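

In this assay, among these compounds, the aromatic carbon that carried fluoro, bromo and tert-butyl now proves able to separate members, since nitro there gives the only number among them, and the change is an at least 27-fold lower number from compound 3 to compound 4 (1.43 log units; beyond the scatter). Measured against the other two groups, the change is an at least 27-fold lower number from compound 2 to compound 4 (1.43 log units; beyond the scatter) and an at least 27-fold lower number from compound 1 to compound 4 (1.43 log units; beyond the scatter), so a replacement at this one place is enough to bring a compound off the limit. The steps among compounds 1, 2 and 3 still cannot be read, and the limit remains the commonest result in the set: the limit of > 1000000 nM in this assay, at which 3 of the 4 values shown sit.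

With a single numerical value, no order among groups at this place can be drawn. As far as these compounds go, whether nitrile, an amine or a carboxylic acid at the same carbon would also leave the limit remains open.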